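The source may hold more compounds than are shown below. What is called first, only, known or untested is meant among the compounds shown, and "the series" means these compounds.

Measured in a functional assay on U-87MG ATCC cells (Homo sapiens) for antiproliferative activity; on this read-out lower numbers stand for stronger inhibition and higher numbers for weaker inhibition:
- compound 1 `Cc1c2c(n3c1CCN(C)C[C@@H](C)[C@H](C)Nc1cc-3ccc1C(N)=O)CC(C)(C)CC2=O`: 49 nM
- compound 2 `COCCC(=O)N1CCCc2c(C)c3c(n2-c2ccc(C(N)=O)c(c2)N[C@@H](C)[C@@H]1C)CC(C)(C)CC3=O`: 80 nM

Within the data shown here, these two values lie within the usual scatter of each other, so compound 1 stands level with the only other measured compound, and no ranking can be drawn between them.

Compound 3 `Cc1c2c(n3c1CCN(C(=O)C1(N)CC1)C[C@@H](C)[C@H](C)Nc1cc-3ccc1C(N)=O)CC(C)(C)CC2=O` has not yet been measured. It keeps the core of compound 1 but has (1-aminocyclopropyl)carbonyl in place of methyl on an amine nitrogen in a ring. Among the measured compounds shown here, this is a sizeable change at a single place, yet no measured pair shows a step of this kind, so the data give no direct guide to its effect.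

The one indirect hint comes from compound 2, which also has a carbonyl on a ring nitrogen and gives 80 nM in the same test. On that slim basis, the expected 1.0-fold higher number from compound 1 to compound 3 (0.01 log units; within the scatter) stays within the scatter, with neither direction favoured. For compound 3 the estimated value is 50 nM, with an expected range from 15 nM to 170 nM.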

Compound 3, half-maximal inhibitory concentration: 85 nM
Estimate against measurement, compound 3: 1.7-fold (0.23 log units) below; measured number inside the range.
By their numbers in this assay, from the lowest: compounds 1, 2 and 3 (each within the scatter of the next).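

In this assay, the amine nitrogen in the ring now has a direct comparison, and replacing methyl with (1-aminocyclopropyl)carbonyl gives a 1.7-fold higher number from compound 1 to compound 3 (0.24 log units; within the scatter). This swap is far from small: 1 heavy atom leaves and 6 enter, bringing a three-membered ring, a hydrogen-bond donor and 2 hydrogen-bond acceptors, yet the antiproliferative read-out of compound 3 cannot be told apart from that of compound 1. The results therefore show that this position can carry a much larger group without a change beyond the usual scatter in this test, although nothing measured here accounts for this.

Because the carbonyl, the three-membered ring and the amino group all arrive together, this single step cannot show what each contributes. It also leaves open whether a simple acetyl group, a carboxylic acid or a longer chain on the same nitrogen would stay level with compound 1 or move the number beyond the scatter.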